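A few compounds are considered here, and "the series" means these few. Any claim that something is new, unique, unknown or untested is made for them only; others in the source may bear on it.

Measured so far in a functional assay on VCaP cells (Homo sapiens) for antiproliferative activity, read by CCK-8 assay, with a stated time of 6 days; on this read-out higher numbers stand for weaker inhibition and lower numbers for stronger inhibition:

- compound 1 `C[C@@H](Cn1ccc(-c2ccc(C#N)c(Cl)c2)n1)NC(=O)c1ccccc1` is recorded as "not determined" (no result reported)
- compound 2 `CC(=O)c1cccc(NC(=O)C(C)Cn2ccc(-c3ccc(C#N)c(Cl)c3)n2)c1` reads 2980 nM

Compound 1 therefore has no number in this assay, so it offers no starting value and cannot be ranked against compound 2. Compound 3 `C[C@@H](Cn1ccc(-c2ccc(C#N)c(Cl)c2)n1)NS(=O)(=O)c1cn(C)cn1` has yet to be measured. The structural change leading to it is (1-methyl-1H-imidazol-4-yl)sulfonyl in place of benzoyl on an amine nitrogen. Going by the values given here, no measured step between closely related compounds is available to show what such a change does, and the missing result for compound 1 leaves no baseline for this one. Among the compounds with values here, the only anchor is compound 2 at 2980 nM, and the expectation is that the result in this assay will show no step beyond the usual scatter from that number, in either direction. This expectation rests on very little, so the range is kept wide. For compound 3 the expected value is about 3000 nM, with an estimated range from 700 nM to 10000 nM.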

Compound 3, half-maximal inhibitory concentration: 13600 nM
Compound 3: the middle estimate sits 4.5-fold (0.66 log units) below what was measured; the whole stated range lies below it.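

In this assay, going by these compounds alone, compound 1 is recorded as "not determined" (no result reported) while compound 3 gives 13600 nM and so no step from compound 1 to compound 3 can be read. The compounds shown leave open what (1-methyl-1H-imidazol-4-yl)sulfonyl in place of benzoyl on the amine nitrogen does to this read-out. No evidence bearing on the result is available.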